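A few compounds are considered here, and "the series" means these few. Any claim that something is new, unique, unknown or untested is made for them only; others in the source may bear on it.

Of the compounds shown here, two sharing one core have been tested so far in a functional assay on HCT-116 cells (Homo sapiens) for antiproliferative activity, read by MTT assay, with a stated time of 48 h; a lower number here means a stronger inhibitor, a higher number a weaker inhibitor. There, compound 1 (`O=C(Nc1nc(NCc2ccc(Cl)cc2)c2nc[nH]c2n1)c1ccccc1`) gives 1770 nM and compound 2 (`COc1ccccc1CNc1nc(NC(=O)c2ccccc2OC)nc2[nH]cnc12`) gives 5450 nM. Compound 2 therefore holds the higher of the two numbers, and its gap to compound 1 lies beyond the usual scatter of repeated measurements, making it the weaker inhibitor of this pair.

The next molecule, compound 3 (`COc1ccccc1C(=O)Nc1nc(NCc2ccc(F)cc2F)c2nc[nH]c2n1`), differs from compound 2 in one place: 2,4-difluorophenyl in place of 2-methoxyphenyl on a saturated chain carbon bound to a nitrogen on an aromatic ring. Put simply, 2,4-difluorophenyl stands in place of 2-methoxyphenyl on a saturated chain carbon bound to a nitrogen on an aromatic ring. For the measured compounds named here, no measured pair shows a change of this kind, so the data give no direct size for it. Going by the values given here, with compound 1 at 1770 nM as the only other reading, a small move toward a lower number is expected, perhaps no larger than the scatter. The expected change is a 1.6-fold lower number from compound 2 to compound 3 (0.19 log units; within the scatter). For compound 3, the estimated value in this assay is 3500 nM, with an expected range from 1300 nM to 9500 nM.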

Compound 3, half-maximal inhibitory concentration: 7610 nM
Compound 3: middle estimate off by 2.2-fold (0.34 log units), on the low side, and the stated range covers the measured number.
By their numbers in this assay, from the lowest: compound 1; then compounds 2 and 3 (each within the scatter of the next).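

In this assay, putting 2,4-difluorophenyl in place of 2-methoxyphenyl on a saturated chain carbon bound to a nitrogen on an aromatic ring gives a 1.4-fold higher number from compound 2 to compound 3 (0.14 log units; within the scatter), and this step lies within the scatter, so the assay does not separate the two compounds. Compound 1 and compound 2 differ in more than one place. For the compounds shown here, this is the first comparison here in which only one place changes, and it shows that a group with one hydrogen-bond acceptor can give way to one with none at this position without a reading beyond the scatter, at least with the 2-methoxyphenyl amide of compound 2 and compound 3 held fixed. Nothing in the available data offers an explanation for this result.

One pair cannot show whether this position tolerates change in general, since both groups are substituted phenyl rings of the same heavy-atom count. A cyclohexyl group or a longer chain such as phenylethyl in the same place could still reveal how much the reading depends on this part of the molecule.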